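Replacing an Aryl Amide with a Butyl Urea

The compounds below may be only part of what the source reports. "The series", "measured", "known", "first", "only" and "open" are said of these compounds alone.

Measured compounds:
Compound 1 `Cc1ccc(C(=O)Nc2cc3nc(C4CCCCC4)[nH]c3cc2N2CCCC2)cc1`: > 100 ug/mL
Compound 2 `Cc1ccc(C(=O)Nc2cc3nc(C4CCCCC4)[nH]c3cc2N(C)C)cc1`: > 100 ug/mL

In an ADME assay on Vero cells (Chlorocebus sabaeus) for cytotoxicity, read by resazurin assay, with a stated time of 3 days (on this read-out higher numbers stand for weaker inhibition and lower numbers for stronger inhibition), compound 1 gives > 100 ug/mL, which is a limit of the assay and not a number. Compound 2 in this assay likewise gives > 100 ug/mL, again a limit. Among the compounds with values here, the only measured step, a step that the two limits leave unreadable from compound 1 to compound 2, is a dimethylamino in place of pyrrolidin-1-yl on an aromatic carbon; its size cannot be read because of the limit of > 100 ug/mL in this assay, at which 2 of the 2 values shown sit. Compound 1 therefore stands at that limit, with nothing above or below it to set a scale.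

Compound 3 `CCCCNC(=O)Nc1cc2nc(C3CCCCC3)[nH]c2cc1N1CCCC1` is the next step from compound 1: butylamino in place of 4-methylphenyl on a carbonyl carbon. The change touches the carbonyl carbon and its neighbouring amide-type nitrogen, not the aromatic carbon altered in the measured step, so that step bears on it only indirectly, by showing that a change elsewhere on the shared core left the read-out at the limit. Within the data shown here, no step in the data points either way, so no movement beyond the scatter is expected in this assay. The estimated step is a step that the limit leaves unreadable from compound 1 to compound 3. Compound 3 is expected to give about 130 ug/mL, within 60 ug/mL to 300 ug/mL, most probably again reported as a limit.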

Compound 3, half-maximal inhibitory concentration: > 100 ug/mL
Compound 3: a limit, no number; the forecaster's own chance of this, stated with the estimate: 75%; the middle value is on the limit's open side.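

In this assay compound 3 gives > 100 ug/mL, which is a limit of the assay and not a number. The step from compound 1 to compound 3 therefore cannot be read, because both compounds sit at the same limit: the limit of > 100 ug/mL in this assay, at which 3 of the 3 values shown sit. From the compounds shown here alone, what stays open is where the true values of compound 1, compound 2 and compound 3 lie, and whether butylamino in place of 4-methylphenyl on the carbonyl carbon changes the read-out at all.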